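This account rests on a few compounds, and the source may have more. Where it says the series, first, only, none or still open, it means among the compounds named here.

Two members of the series have been measured in an assay on isolated protein for inhibition of Amine oxidase [flavin-containing] B (Homo sapiens), read by fluorescence, with a stated time of 1 h, tested at 10 uM; on this read-out lower numbers stand for less inhibition and higher numbers for more inhibition at the one concentration tested (going by the name of the read-out). Compound 1 `c1ccc(CNc2ccc3nc(-c4ccccc4)oc3n2)cc1` gives 4.8% in this assay, and compound 2 `c1ccc(-c2nc3ccc(N4CCCCCC4)nc3o2)cc1` gives 57.9% in this assay. Of the two numbers, compound 2 stands highest, and the gap to compound 1 lies beyond the usual scatter of repeated measurements, so the inhibition in this assay is higher for compound 2 than for compound 1.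

Compound 3 `c1ccc(-c2nc3ccc(N4CCCCC4)nc3o2)cc1` has not yet been measured. It differs from compound 2 in one place: piperidin-1-yl in place of azepan-1-yl on an aromatic carbon. The seven-membered non-aromatic ring with one hetero atom leaves and a six-membered non-aromatic ring with one hetero atom enters, with no change in hydrogen-bond donors, acceptors or net charge.

Among the measured compounds shown here, no pair of measured compounds shows this kind of change, so the expected step from compound 2 to compound 3 rests on the closeness of the two groups alone; a modest drop, or none beyond the scatter, is expected, a number 12.9 percentage points lower from compound 2 to compound 3 (beyond the scatter). Compound 3 is estimated at 45% in this assay, within a range of 20% to 70%.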

Compound 3, a percentage reported as inhibition, at one concentration (the size of the read-out at that concentration, not a potency): 86.8%
For compound 3 the middle estimate is 41.8 percentage points below the measured one; the whole stated range lies below it.
By their numbers in this assay, from the lowest: compound 1; then compound 2; then compound 3.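

In this assay, the position on an aromatic carbon next to the ring nitrogen proves sensitive to the size of the non-aromatic ring: piperidin-1-yl in place of azepan-1-yl gives a number 28.9 percentage points higher from compound 2 to compound 3 (beyond the scatter). The two groups carry the same counts of hydrogen-bond donors and acceptors and no net charge, so a change of one ring carbon is enough to separate compound 2 from compound 3 beyond the scatter. No measurement at hand bears on why the two rings differ.

Among the compounds shown here, with only two ring sizes, no trend can be drawn, and whether the five-membered pyrrolidin-1-yl ring continues the rise remains open. Also open, going by these compounds, is how this position responds to morpholin-4-yl, with its ring oxygen, or to an open-chain diethylamino group.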